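Hydroxymethyl on the aryl ring of a bicyclic thiazole alcohol

The source may report more compounds than this note shows. Statements on the series, on what has been measured and on what is new or still open speak of the compounds shown alone.

The study concerns two measured compounds and one that awaits testing. Compound 1 `OC1CCCc2nc(-c3ccc(N4CCCC4)cc3)sc21` was examined in a functional assay on HCT-116 cells (Homo sapiens) for cytotoxicity, read by sulforhodamine B assay, with a stated time of 2 days (on this read-out higher numbers stand for weaker inhibition and lower numbers for stronger inhibition), where compound 1 gives 1530 nM. Of the two numbers recorded, this is the highest. The nearest neighbour is compound 2 `Cc1cc(N(C)C)ccc1-c1nc2c(s1)[C@@H](O)CCC2`, which in this assay gives 560 nM; its number is lower than that of compound 1 by a margin beyond the usual scatter, though compound 2 differs from compound 1 in more than one place, so no single step can be read from the pair.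

The untested compound 3 `OCc1cc(N2CCCC2)ccc1-c1nc2c(s1)C(O)CCC2` is derived from compound 1 by one change: hydroxymethyl in place of hydrogen on an aromatic carbon. The new group sits on an aromatic carbon of a six-membered aromatic ring of carbon only, ortho to a large group and meta to a pyrrolidin-1-yl group.

For the measured compounds named here, no measured step isolates this change. The account expects a modest move toward a lower number, at the edge of the scatter, so that compound 3 is estimated at 900 nM, within 300 nM to 2700 nM, which means an expected step of a 1.7-fold lower number from compound 1 to compound 3 (0.23 log units; within the scatter).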

Compound 3, half-maximal inhibitory concentration: 42 nM
Beside the measured number, compound 3's estimate is 21-fold (1.33 log units) above it; the whole stated range lies above it.
By their numbers in this assay, from the lowest: compound 3; then compound 2; then compound 1.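

In this assay, for the compounds shown here, the replacement of hydrogen by hydroxymethyl on this aromatic carbon gives a 36-fold lower number from compound 1 to compound 3 (1.56 log units; beyond the scatter) in a single change, and this is the first step in the set that can be read on its own. It shows that this place on the six-membered aromatic ring, ortho to a large group and meta to a pyrrolidin-1-yl group, is far from indifferent to what stands on it, since a group of only 2 heavy atoms moves the number well beyond the scatter. No evidence is at hand that bears on why the step is so large.

With a single group tried at this place, the compounds leave open whether the step belongs to the hydroxyl or to the added carbon, a question that a plain methyl, a methoxymethyl, an aminomethyl or a carboxylic acid on the same carbon would help to settle. They also leave open whether a longer chain such as 2-hydroxyethyl would keep the step, and whether hydroxymethyl would do the same on any other carbon of this ring.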